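The compounds below may be only part of what the source reports. "The series", "measured", "known", "first", "only" and "open" are said of these compounds alone.

Working notes on the hydrazone series.

Compound 1, `CNc1ncccc1C(=O)N/N=C/c1ccccc1`, gives 14.8% in a functional assay on the whole organism (strain Wistar) for inhibition, with Rattus norvegicus as the target, read by paw edema, with a stated time of 4 h, at a dose of 10 mg/kg by the intraperitoneal route; on this read-out lower numbers stand for less inhibition and higher numbers for more inhibition at the one dose given (going by the name of the read-out). Among the measured compounds shown here, compound 2, `CNc1ncccc1C(=O)N/N=C/c1cccc(Cl)c1`, gives 40.4% in this assay; the single step between them, chloro in place of hydrogen on an aromatic carbon, is a number 25.6 percentage points higher from compound 1 to compound 2 (beyond the scatter). On the two numbers in hand compound 2 stands highest, with compound 1 the only other point, lower by a margin beyond the scatter.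

The next member is compound 3, `CNc1ncccc1C(=O)N/N=C/c1cccc(OC)c1`. Relative to compound 2 the change is methoxy in place of chloro on an aromatic carbon.

For the measured compounds named here, no measured step replaces chloro by methoxy, so the only bearing comes from the chloro-for-hydrogen step, a number 25.6 percentage points higher from compound 1 to compound 2 (beyond the scatter), which shows that a substituent at this place can shift the read-out by a modest margin. From the compounds shown here alone, whether methoxy holds that gain is untested. The expectation is a step of a number 9.4 percentage points lower from compound 2 to compound 3 (within the scatter) in this assay, downward, of a size near or within the scatter, since the substituted carbon is kept but the group differs.

Compound 3 is estimated at 31%, within 13% to 49%.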

Compound 3, a percentage reported as inhibition, in the whole organism at one dose (the size of the read-out at that dose, not a potency): 42.3%
For compound 3 the middle estimate is 11.3 percentage points below the measured one; measured number inside the range.
By their numbers in this assay, from the lowest: compound 1; then compounds 2 and 3 (each within the scatter of the next).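

The exchange of chloro for methoxy gives a number 1.9 percentage points higher from compound 2 to compound 3 (within the scatter) in this assay and so separates the two groups by nothing that can be read in these numbers. Measured against the unsubstituted member, methoxy gives a number 27.5 percentage points higher from compound 1 to compound 3 (beyond the scatter) and thus provides a second substituent at this aromatic carbon with a gain beyond the scatter, so the gain first seen with chloro is not confined to chloro. Within these three compounds, a chlorine atom and a group of one carbon and one oxygen lead to the same place on the read-out, which shows that the exact identity of the substituent matters less here than its presence, as far as these two groups go. Nothing in hand gives a reason for this shared gain.

From the compounds shown here alone, whether the gain persists with an amine, a carboxylic acid or a longer alkoxy chain on this carbon remains open, as does the question of whether any such group could move the read-out beyond the level shared by chloro and methoxy. Also open, going by these compounds, is how chloro or methoxy would behave on the other carbons of the same ring.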